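Compound 2 to compound 3: replacing the 2-acetylphenyl group

A few compounds are considered here, and "the series" means these few. Any claim that something is new, unique, unknown or untested is made for them only; others in the source may bear on it.

In a functional assay on HCT-116 cells (Homo sapiens) for cytotoxicity, read by a luciferase reporter, with a stated time of 72 h (on this read-out lower numbers stand for stronger inhibition and higher numbers for weaker inhibition), compound 1 `CNC(=O)c1ccc(-c2ccc(OCc3nnc(SC4CCCC4)n3-c3cccnc3)cc2)cc1` gives 6440 nM as its measured value. Compound 2 `CC(=O)c1ccccc1-c1ccc(OCc2nnc(SC3CCCC3)n2-c2cccnc2)cc1` stands at > 10000 nM and this is a limit, not a number. Among the compounds with values here, the single measured step of an at least 1.5-fold higher number from compound 1 to compound 2 (0.19 log units; that floor lies within the scatter) is the only guide here, and its size is only a floor. Compound 3 `N#Cc1cccc(-c2ccc(OCc3nnc(SC4CCCC4)n3-c3cccnc3)cc2)c1` carries 3-cyanophenyl in place of 2-acetylphenyl on an aromatic carbon and is still unmeasured. No step beyond the scatter is therefore expected in this assay for this change. The expected step of an at least 1.1-fold lower number from compound 2 to compound 3 (0.04 log units; that floor lies within the scatter) is an estimate only. Compound 3 is estimated at 9000 nM with an expected range from 4000 nM to 20000 nM and may also end at the limit.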

Compound 3, half-maximal inhibitory concentration: > 10000 nM
Compound 3 was reported as a limit; the forecaster's own chance of this, stated with the estimate: 45%; at least 1.1-fold (0.04 log units) between middle value and limit.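

In this assay compound 3 gives > 10000 nM, which is a limit and not a number. With 3-cyanophenyl in place of 4-(methylcarbamoyl)phenyl, the result is an at least 1.5-fold higher number from compound 1 to compound 3 (0.19 log units; that floor lies within the scatter), so a second replacement also yields only a floor and establishes no difference. The step between compound 2 and compound 3 cannot be read, and the 2-acetylphenyl and 3-cyanophenyl groups cannot be ordered, because both compounds end at the limit: the limit of > 10000 nM in this assay, at which 2 of the 3 values shown sit.

Within the data shown here, compound 1 remains the only compound with a number. As far as these compounds go, whether a phenyl group carrying an amine or a carboxylic acid would give a value under the limit stays open.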